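The compounds below may be only part of what the source reports. "The series", "measured", "known", "first", "only" and "open" are said of these compounds alone.

Of the compounds shown here, three built on a shared core have been measured so far. In a functional assay on HT-29 cells (Homo sapiens) for inhibition, read by CCK-8 assay, with a stated time of 24 h (on this read-out lower numbers stand for stronger inhibition and higher numbers for weaker inhibition), compound 1 (`O=C1Nc2ccccc2/C1=C/c1ccc(-c2cn(-c3ccc(F)cc3)nn2)cc1`) gives 17700 nM. Compound 2 (`Cc1ccccc1-n1cc(-c2ccc(C=C3C(=O)Nc4ccc(F)cc43)cc2)nn1`) gives 5870 nM in the same test, and compound 3 (`O=C1Nc2ccc(F)cc2/C1=C/c1ccc(-c2cn(-c3ccccc3Cl)nn2)cc1`) gives 5950 nM. Compound 2 and compound 3 therefore lie within the scatter of each other, while compound 1 stands at a higher number than compound 2, a gap beyond the scatter.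

Compound 4 (`N#Cc1ccccc1-n1cc(-c2ccc(C=C3C(=O)Nc4ccc(F)cc43)cc2)nn1`) has not yet been measured. It departs from compound 2 in one place, with cyano in place of methyl on an aromatic carbon, ortho to a large group, so that 2-methylphenyl becomes 2-cyanophenyl: cyano in place of methyl on an aromatic carbon.

For the measured compounds named here, no measured pair of compounds shows the size of this change, so the data offer no direct guide to it. The expectation rests on compound 2 at 5870 nM and on compound 3 at 5950 nM, two values that sit level. In this assay, no step beyond the scatter is expected, with at most a slight drift toward a higher number. The estimated change is a 1.2-fold higher number from compound 2 to compound 4 (0.08 log units; within the scatter). For compound 4 the expected value is 7000 nM, with an estimated range from 2800 nM to 18000 nM.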

Compound 4, half-maximal inhibitory concentration: > 13900 nM
Compound 4: a limit, no number; the forecaster's own chance of this, stated with the estimate: 5%; middle value at least 1.9-fold (0.29 log units) from the limit.
By their numbers in this assay, from the lowest: compounds 2 and 3 (each within the scatter of the next); then compound 1.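

Cyano in place of methyl on an aromatic carbon, ortho to a large group, gives an at least 2.3-fold higher number from compound 2 to compound 4 (0.37 log units; beyond the scatter) in this assay, so this place does not accept every group equally. For the compounds shown here, compounds 2 and 3, which differ only in methyl and chloro at this place, had stood within the scatter of each other, so the earlier compounds gave no sign that a change here could carry weight. For compound 4 the result > 13900 nM is a limit of the assay and not a number, so the step is a minimum and its full size cannot be read: the limit of > 13900 nM in this assay, at which 1 of the 4 values shown sits.

The compounds shown leave open whether the weaker result belongs to cyano alone or would also come with other groups at this place, such as a methoxy group, an amine or a carboxylic acid. They also leave open whether cyano in place of methyl would give a similar step on the core of compound 1.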